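Exchanging a Branched Side Chain for a Straight One

This account rests on a few compounds, and the source may have more. Where it says the series, first, only, none or still open, it means among the compounds named here.

Compound 2 `CC(C)(C)c1cc(=O)c2ccc(O)cc2o1` carries a tert-butyl group on the shared core. In an assay on isolated protein for inhibition of Polyunsaturated fatty acid lipoxygenase ALOX12 (Homo sapiens) (on this read-out lower numbers stand for stronger inhibition and higher numbers for weaker inhibition), compound 2 gives > 100000 nM, which is a limit of the assay rather than a measured number. Compound 1 `CC(C)c1cc(=O)c2ccc(O)cc2o1` differs from compound 2 only by a methyl group on the saturated carbon attached to the core. In this assay compound 1 gives > 100000 nM, which is again a limit. The step that the two limits leave unreadable from compound 1 to compound 2 therefore cannot be read in size or direction, since both of its ends rest on (the limit of > 100000 nM in this assay, at which 2 of the 2 values shown sit).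

Compound 3 `CCCCCc1cc(=O)c2ccc(O)cc2o1` has not yet been measured. It differs from compound 2 by pentyl in place of tert-butyl on an aromatic carbon. Within the data shown here, the only measured step, from a branched group to a slightly larger branched group, offers no readable size, and no other step touches a straight chain. With both known compounds sitting at the limit, no measurable inhibition is in sight. Compound 3 is therefore expected to give 100000 nM in this assay, within a range from 30000 nM to 300000 nM. The implied step a number no higher from compound 2 to compound 3 (the limit leaves the size open) is expected to stay within the usual scatter.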

Compound 3, half-maximal inhibitory concentration: > 100000 nM
Compound 3: only a limit was reported; the forecaster's own chance of this, stated with the estimate: 85%; the middle value sits exactly at the limit.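

In this assay compound 3 gives > 100000 nM as a limit of the assay and not a number, so the steps to compound 3 from compound 1 and from compound 2 cannot be read in size or direction: the limit of > 100000 nM in this assay, at which 3 of the 3 values shown sit.

On these data alone, whether any side chain on the shared core gives a readable number in this assay stays open.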